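The source may hold more compounds than are shown below. What is called first, only, known or untested is meant among the compounds shown, and "the series" means these compounds.

Working notes on the series.

Going by the values given here, compound 1, `CC(C)(O)C(CCC/C=C(\c1ccccc1)c1cccnc1)C(=O)O`, gives 42 nM in an assay (Equus caballus) for inhibition of Thromboxane-A synthase (Homo sapiens), using microsomes (a higher number here means a weaker inhibitor, a lower number a stronger inhibitor), the lowest of the three numbers so far. Compound 3, `O=C(O)C(CCC/C=C(\c1ccccc1)c1cccnc1)C1=CCCC1`, gives 60 nM in this assay, and the step of a 1.4-fold higher number from compound 1 to compound 3 (0.15 log units; within the scatter) shows that a change at the carbon bearing the carboxyl leaves the number essentially where it was. Among the compounds with values here, compound 2, `O=C(O)CCCC/C=C(\c1cccnc1)c1cccc(Br)c1`, gives 180 nM in this assay, a number beyond the scatter from that of compound 1, though no single-point step connects the two.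

Compound 4, `CC(C)(CCCC/C=C(\c1ccccc1)c1cccnc1)C(=O)O`, is not yet measured. It differs from compound 1 as follows: 2-carboxy-2-methylpropyl in place of 1-carboxy-2-hydroxy-2-methylpropyl on a saturated chain carbon, three bonds along the chain from a double-bonded chain carbon. Within the data shown here, the only measured step that bears on this change is the one from compound 1 to compound 3, which was within the scatter; that step kept the carboxyl on the same chain carbon, whereas compound 4 moves it and drops the hydroxyl, so the comparison is loose. For compound 4 the expected step from compound 1 is a 1.7-fold higher number from compound 1 to compound 4 (0.22 log units; within the scatter), a modest weakening at most. Compound 4 is therefore estimated at 70 nM in this assay, within a range of 25 nM to 200 nM.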

Compound 4, half-maximal inhibitory concentration: 45 nM
Compound 4: middle estimate off by 1.6-fold (0.19 log units), on the high side, and the stated range covers the measured number.
By their numbers in this assay, from the lowest: compounds 1, 4 and 3 (each within the scatter of the next); then compound 2.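

The step (a 1.1-fold higher number from compound 1 to compound 4 (0.03 log units; within the scatter)) shows that in this assay 2-carboxy-2-methylpropyl can take the place of 1-carboxy-2-hydroxy-2-methylpropyl on this saturated chain carbon without a change beyond the scatter. Compound 3 also lacks the hydroxyl but carries cyclopent-1-en-1-yl, whereas compound 4 lacks the hydroxyl with no ring entering, so neither the hydroxyl nor that ring is required for a number at this level. No measurement at hand bears on why the number holds.

Still open, going by these compounds, is whether the two methyl groups of 2-carboxy-2-methylpropyl matter when set against a plain unbranched chain on the same core. Also open, on these data alone, is what a primary amide or a tetrazole would do in place of the carboxylic acid.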